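This account rests on a few compounds, and the source may have more. Where it says the series, first, only, none or still open, it means among the compounds named here.

Three sugar-linked compounds that share a core have been tested for how harmful they are to cultured cells. Compound 1, `CC(=O)C[C@H]1O[C@@H](On2cc(CN3C(=O)C(=O)c4ccccc43)nn2)[C@H](OC(C)=O)[C@@H](OC(C)=O)[C@@H]1OC(C)=O`, carries an acetylated sugar; in an ADME assay on Vero cells (Chlorocebus sabaeus) for cytotoxicity, read by fluorescence and resazurin assay, with a stated time of 3 days (on this read-out lower numbers stand for higher toxicity in this test and higher numbers for lower toxicity in this test), compound 1 gives 137000 nM. Compound 2, `CC1(C)O[C@H]2O[C@H](Cn3cc(CN4C(=O)C(=O)c5ccccc54)nn3)[C@H](O)[C@H]2O1`, has a different, ring-protected sugar. In this assay compound 2 gives > 200000 nM, which is a limit of the test rather than a number; this is the case described as the limit of > 200000 nM in this assay, at which 1 of the 3 values shown sits. Compound 3, `CC(=O)C[C@H]1O[C@@H](On2cc(CN3C(=O)/C(=N\Nc4ccccc4)c4ccccc43)nn2)[C@H](OC(C)=O)[C@@H](OC(C)=O)[C@@H]1OC(C)=O`, adds a phenylhydrazone arm to the core of compound 1, and in this assay compound 3 gives 108000 nM. Compound 3 and compound 1 sit within the usual scatter of each other, so the two numbers cannot be told apart.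

Compound 4, `CC(=O)C[C@H]1O[C@@H](On2cc(CN3C(=O)/C(=N\Nc4ccc(Br)cc4)c4ccccc43)nn2)[C@H](OC(C)=O)[C@@H](OC(C)=O)[C@@H]1OC(C)=O`, is compound 3 with one small change: bromo in place of hydrogen on an aromatic carbon. Within the data shown here, no measured pair in this set shows what such a change does, so the expectation rests on how closely compound 3 and compound 1 sit together. The step from compound 3 to compound 4 in this assay is expected to be small, a 1.2-fold lower number from compound 3 to compound 4 (0.08 log units; within the scatter), not clearly beyond the scatter. Compound 4 is therefore estimated at 90000 nM, with a likely range from 45000 nM to 180000 nM.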

Compound 4, half-maximal cytotoxic concentration: 116000 nM
Compound 4: middle estimate off by 1.3-fold (0.11 log units), on the low side, within the range that was stated.
By their numbers in this assay, from the lowest: compounds 3, 4 and 1 (each within the scatter of the next). At a limit, above all of these: compound 2.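

Among these compounds, this is the first step in the set between two compounds that differ in only one place: in this assay, bromo in place of hydrogen on an aromatic carbon, para to a large group, gives a 1.1-fold higher number from compound 3 to compound 4 (0.03 log units; within the scatter) and so leaves the two compounds impossible to tell apart. At this position, then, going from phenyl to 4-bromophenyl adds one heavy atom on the arm of compound 3 without producing a difference that this test can resolve. The earlier compounds could only hint at this through the closeness of compound 1 and compound 3, whereas this pair isolates one atom on one ring, and nothing measured here explains why the swap leaves so little mark.

From the compounds shown here alone, a single bromine at a single carbon says little about the ring as a whole, so it remains open whether an amine or a carboxylic acid at the same carbon would also stay within the scatter of compound 3. Going by these compounds, it is equally open whether bromo on a different carbon of that ring, or a longer chain in its place, would give a clear difference in this test.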